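Thiophen-3-yl for furan-3-yl on the shared core

The source may hold more compounds than are shown below. What is called first, only, known or untested is meant among the compounds shown, and "the series" means these compounds.

Among the measured compounds shown here, compound 3 `COC(=O)c1nc(-c2ccoc2)n(-c2ccc(C(F)(F)F)cc2)n1` is one of three compounds measured in a functional assay on NPC-TW01 cells (Homo sapiens) for inhibition, read by MTT assay, with a stated time of 72 h; a higher number here means a weaker inhibitor of growth, a lower number a stronger inhibitor of growth. In this assay compound 3 returns > 100000 nM, which is a limit of the assay and not a number. Compound 1 `COC(=O)c1nc(C2CCCC2)n(-c2ccc(C(F)(F)F)cc2)n1` gives 56400 nM in this assay. Compound 2 `COC(=O)c1nc(C2CCCCC2)n(-c2ccc(C(F)(F)F)cc2)n1` returns > 100000 nM in this assay, again a limit rather than a number. This matches (the limit of > 100000 nM in this assay, at which 2 of the 3 values shown sit). The measured steps starting from compound 1 are an at least 1.7-fold higher number from compound 1 to compound 2 (0.24 log units; that floor lies within the scatter) and an at least 1.7-fold higher number from compound 1 to compound 3 (0.24 log units; that floor lies within the scatter), both of them floors that sit within the scatter; the step that the two limits leave unreadable from compound 2 to compound 3 cannot be sized. Compound 4 `COC(=O)c1nc(-c2ccsc2)n(-c2ccc(C(F)(F)F)cc2)n1` carries the change (thiophen-3-yl in place of furan-3-yl on an aromatic carbon). For the measured compounds named here, no measured step tests this exchange, and the steps that alter the group at the same place start from compound 1 and end at the limit. The expectation in this assay is that compound 4 remains near the limit, with an estimated step of a number no higher from compound 3 to compound 4 (the limit leaves the size open) no larger than the scatter. Compound 4 is estimated at 100000 nM, within 40000 nM to 300000 nM.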

Compound 4, concentration for 50% growth inhibition: 34900 nM
For compound 4 the middle estimate is 2.9-fold (0.46 log units) above the measured one; the measured number lies below the stated range.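

In this assay the exchange of furan-3-yl for thiophen-3-yl gives an at least 2.8-fold lower number from compound 3 to compound 4 (0.45 log units; beyond the scatter) and so brings a five-membered aromatic ring at this place off the limit of the assay, with oxygen replaced by sulfur and the heavy-atom count unchanged. The same thiophen-3-yl in place of cyclohexyl gives an at least 2.8-fold lower number from compound 2 to compound 4 (0.45 log units; beyond the scatter) so a readable value at this place is not confined to the cyclopentyl of compound 1. Thiophen-3-yl and cyclopentyl are not told apart here, the step being a 1.6-fold lower number from compound 1 to compound 4 (0.21 log units; within the scatter) and the two groups thus sharing a readable value despite their different rings.

Going by these compounds, whether an amine or a carboxylic acid at this place would give a readable value remains open. How far compound 2 and compound 3 truly lie from compound 4 also stays open, these two values being limits and not numbers: the limit of > 100000 nM in this assay, at which 2 of the 4 values shown sit.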